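A few compounds are considered here, and "the series" means these few. Any claim that something is new, unique, unknown or untested is made for them only; others in the source may bear on it.

Measured compounds, with values from (a functional assay on HeLa cells (Homo sapiens) for antiproliferative activity, with a stated time of 24 h; a lower number here means a stronger inhibitor, a higher number a weaker inhibitor)
- Compound 1 (`Oc1cc2c(cc1O)CN(C(=S)NCc1ccccc1)CC2`) gives only a limit (> 100000 nM)
- Compound 2 (`Oc1cc2c(cc1O)C(c1ccccc1)N(C(=S)NCc1ccc(Cl)cc1)CC2`) gives only a limit (< 5000 nM)

Compound 2 therefore has no exact number, and its limit sits at the lower, stronger end of the two values shown. Compound 3 (`CC(C)C1c2cc(O)c(O)cc2CCN1C(=S)NCc1ccc(Cl)cc1`) carries isopropyl in place of phenyl on a saturated ring carbon, next to the ring nitrogen (isopropyl in place of phenyl on a saturated ring carbon). For the measured compounds named here, no measured step covers this change, so a moderate shift towards weaker inhibition in (this assay) is expected, with an estimated (an at least 1.6-fold higher number from compound 2 to compound 3 (0.20 log units; that floor lies within the scatter)). For compound 3 the expected value is (8000 nM), with an estimated range from (2000 nM) to (40000 nM).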

Compound 3, half-maximal inhibitory concentration: 35000 nM
Beside the measured number, compound 3's estimate is 4.4-fold (0.64 log units) below it; the range from low to high includes it.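

In this assay, the saturated ring carbon next to the ring nitrogen is sensitive to which group it carries: isopropyl in place of phenyl gives an at least 7.0-fold higher number from compound 2 to compound 3 (0.84 log units; beyond the scatter). This step is only a floor because compound 2 has a limit, not a number: the limit of < 5000 nM in this assay, at which 1 of the 3 values shown sits.

Going by these compounds, the true size of the step remains open, as does whether it follows from losing the aromatic ring or from the isopropyl itself. Cyclohexyl, methyl or a methoxy-substituted phenyl on this carbon would help separate these readings.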